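The compounds below may be only part of what the source reports. "The series", "measured", "known", "first", "only" and "open" are said of these compounds alone.

Compound 1 `CN(C)c1ccc(C(=O)OCC2(CO)C/C(=C\c3ccc([N+](=O)[O-])cc3)C(=O)O2)cc1` gives the lowest of the two numbers seen in an assay on isolated protein for binding affinity to Ras guanyl-releasing protein 3 (Homo sapiens) (a higher number here means a weaker inhibitor, a lower number a stronger inhibitor), 3.8 nM, while compound 2 `CN(C)c1cccc(C(=O)OCC2(CO)C/C(=C\c3ccccc3[N+](=O)[O-])C(=O)O2)c1` gives 16.4 nM in this assay. Compound 3 `O=C1OC(CO)(COC(=O)c2ccc([N+](=O)[O-])cc2)C/C1=C\c1ccc([N+](=O)[O-])cc1` differs from compound 1 by a nitro in place of dimethylamino on an aromatic carbon. For the measured compounds named here, no measured pair covers this change, so its effect is unknown; the author expects at most a small step, a 1.6-fold higher number from compound 1 to compound 3 (0.20 log units; within the scatter), in the weakening direction and possibly none beyond the scatter. Compound 3 is therefore estimated at 6 nM, in the range 2 nM to 20 nM in this assay.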

Compound 3, inhibition constant: 2.22 nM
Compound 3: middle estimate off by 2.7-fold (0.43 log units), on the high side, within the range that was stated.
By their numbers in this assay, from the lowest: compounds 3 and 1 (each within the scatter of the next); then compound 2.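

Swapping 4-(dimethylamino)phenyl for 4-nitrophenyl gives a 1.7-fold lower number from compound 1 to compound 3 (0.23 log units; within the scatter) in this assay, so the two groups cannot be told apart at this position. Binding at this level therefore does not depend on keeping dimethylamino, and nitro serves here on the same core.

The compounds shown leave open whether other groups on this aromatic carbon, para to a large group, such as a primary amine, a carboxylic acid or a methoxy group, would read the same. Nothing at hand bears on why dimethylamino and nitro read alike.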